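Compound 1 to compound 4: moving the hydroxyl

The compounds below may be only part of what the source reports. "The series", "measured", "known", "first", "only" and "open" are said of these compounds alone.

Values in a functional assay on HepG2 cells (Homo sapiens) for antiproliferative activity, read by MTT assay, with a stated time of 48 h; a lower number here means a stronger inhibitor of growth, a higher number a weaker inhibitor of growth:
- compound 1 `COC(=O)N1N=C(c2cccc(O)c2)CC1c1cc(OC)c(OC)c(OC)c1`: 650 nM
- compound 2 `CCOC(=O)N1N=C(c2cccc(O)c2)CC1c1cc(OC)c(OC)c(OC)c1`: 1790 nM
- compound 3 `COc1cc(C2CC(c3cccc(O)c3)=NN2C(=O)OCc2ccccc2)cc(OC)c1OC`: > 10000 nM, a limit of the assay

Compound 1 holds the lower of the two actual numbers in this assay, while the third value is only a limit. The next compound is compound 4 `COC(=O)N1N=C(c2ccc(O)cc2)CC1c1cc(OC)c(OC)c(OC)c1`, not yet measured. Its difference from compound 1 is 4-hydroxyphenyl in place of 3-hydroxyphenyl on a carbon with a double bond to nitrogen, with the methoxycarbonyl group and the rest of the core unchanged.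

For the measured compounds named here, no measured step touches the hydroxyphenyl group, so the evidence is indirect. All three steps alter the group that compound 1 carries as methoxycarbonyl: a 2.8-fold higher number from compound 1 to compound 2 (0.44 log units; beyond the scatter), an at least 15-fold higher number from compound 1 to compound 3 (1.18 log units; beyond the scatter) and an at least 5.5-fold higher number from compound 2 to compound 3 (0.74 log units; beyond the scatter). They show that this assay responds to structural change in this series, and both steps away from compound 1 raise the number. A modest rise is therefore expected, with low confidence. The expected change is a 2.3-fold higher number from compound 1 to compound 4 (0.36 log units; beyond the scatter). For compound 4 the estimated value is 1500 nM. The expected range for compound 4 runs from 400 nM to 6000 nM.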

Compound 4, concentration for 50% growth inhibition: 7820 nM
Estimate against measurement, compound 4: 5.2-fold (0.72 log units) below; the measured number lies above the stated range.
By their numbers in this assay, from the lowest: compound 1; then compound 2; then compound 4. At a limit, above all of these: compound 3.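

In this assay, for the compounds shown here, the change from 3-hydroxyphenyl to 4-hydroxyphenyl gives a 12-fold higher number from compound 1 to compound 4 (1.08 log units; beyond the scatter), the first measured step at this position. The earlier steps shown here all altered the methoxycarbonyl group, whereas this one shows that the assay also responds at the carbon with a double bond to nitrogen, even though the two groups have the same atoms and the same counts of hydrogen-bond donors and acceptors. Compound 4 gives an actual number, so this step is read in full and not against the limit of the assay: the limit of > 10000 nM in this assay, at which 1 of the 4 values shown sits.

Whether the hydroxyl itself is needed stays open, as no compound shown carries an amine, a methoxy group or an unsubstituted phenyl in its place. Also open, going by these compounds, is whether the same shift has a similar size when an ethoxycarbonyl group replaces methoxycarbonyl.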